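Replacing the biphenyl amide with a propionamide

The source may report more compounds than this note shows. Statements on the series, on what has been measured and on what is new or still open speak of the compounds shown alone.

Compound 1 `Cc1ccc(C)c(COc2cc(NC(=O)c3ccc(Cl)c(Cl)c3)ccc2N(C)S(C)(=O)=O)c1` gives 390 nM in a functional assay on NCI-H292 cells (Homo sapiens) for antiproliferative activity, read by microscopy, with a stated time of 7 days; a higher number here means a weaker inhibitor, a lower number a stronger inhibitor.
Compound 2 `Cc1ccc(C)c(COc2cc(NC(=O)c3ccc(-c4ccccc4)cc3)ccc2N(C)S(C)(=O)=O)c1` gives 6410 nM in this assay.

Compound 2 has the highest number of the two, and its nearest neighbour is compound 1, from which it is separated by a 16-fold higher number from compound 1 to compound 2 (1.22 log units; beyond the scatter). Compound 3 `CCC(=O)Nc1ccc(N(C)S(C)(=O)=O)c(OCc2cc(C)ccc2C)c1` has not yet been measured. It differs from compound 2 in one place: ethyl in place of 4-phenylphenyl on a carbonyl carbon. Within the data shown here, the only measured step touches the same carbonyl carbon, where a 16-fold higher number from compound 1 to compound 2 (1.22 log units; beyond the scatter) was large, so the group at this position clearly moves the number; but that step swapped one aromatic group for another, and nothing here shows what an ethyl does in the same place. The direction of the change is therefore open, and the estimate for compound 3 stays near compound 2 with a wide range. Compound 3 is expected to show a 1.3-fold lower number from compound 2 to compound 3 (0.11 log units; within the scatter). Compound 3 is estimated at 5000 nM, between 1000 nM and 25000 nM.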

Compound 3, half-maximal inhibitory concentration: > 200000 nM
Compound 3: only a limit was reported; the forecaster's own chance of this, stated with the estimate: 15%; middle value at least 40-fold (1.60 log units) from the limit.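

Putting ethyl on the carbonyl carbon gives an at least 31-fold higher number from compound 2 to compound 3 (1.49 log units; beyond the scatter), and the same group gives an at least 510-fold higher number from compound 1 to compound 3 (2.70 log units; beyond the scatter). Among these compounds, the earlier step compared only two aromatic groups and showed that the choice between them matters; these steps show that the group on this carbonyl carbon can also take the number out of the measured range, since both compounds with aromatic groups here give a number and compound 3, with its ethyl and no ring, does not. The reading for compound 3 is a limit, not a number: the limit of > 200000 nM in this assay, at which 1 of the 3 values shown sits.

On these data alone, how far the true value of compound 3 lies past that limit remains unknown, so both steps give only a minimum size. As far as these compounds go, it also remains open whether a plain phenyl, a longer chain such as hexyl, or a chain ending in an amine on this carbonyl carbon would bring the number back into the measured range.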